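This account rests on a few compounds, and the source may have more. Where it says the series, first, only, none or still open, it means among the compounds named here.

The measured compounds:

compound 1, `COC(=O)c1c(NC(=S)Nc2ccccc2)sc2c1CCC2`, giving 14100 nM
compound 2, `COC(=O)c1c(NC(=S)Nc2ccc(C)cc2)sc2c1CCCC2`, giving 10300 nM
compound 3, `CCOC(=O)c1c(N=C(S)Nc2ccc(F)cc2)sc2c1CCC2`, giving 13300 nM

These three numbers come from an assay on HEK-Blue hTLR2 cells for agonist activity at Toll-like receptor 2 (Homo sapiens), with a stated time of 24 h; on this read-out lower numbers stand for an effect already at smaller amounts and higher numbers for an effect only at larger amounts of compound. They all lie within the usual scatter of one another, so compound 2 does not stand apart from compound 1 or compound 3: the three behave alike on this read-out, and none can be called stronger or weaker than another. The next compound, compound 4, `COC(=O)c1c(NC(=S)Nc2ccc(C(F)(F)F)cc2)sc2c1CCCC2`, has not yet been measured in this assay. It differs from compound 2 in one place: trifluoromethyl in place of methyl on an aromatic carbon. Within the data shown here, no measured pair in this set isolates this kind of change, so there is no step in this assay to lean on. With the three known values so close together, the expectation is a step no larger than the scatter, in no firm direction, so the estimated step is a 1.0-fold lower number from compound 2 to compound 4 (0.01 log units; within the scatter). Compound 4 is therefore expected to give about 10000 nM, within a range from 4000 nM to 25000 nM.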

Compound 4, half-maximal effective concentration: 33900 nM
For compound 4 the middle estimate is 3.4-fold (0.53 log units) below the measured one; the whole stated range lies below it.
By their numbers in this assay, from the lowest: compounds 2, 3 and 1 (each within the scatter of the next); then compound 4.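

In this assay, among these compounds, replacing methyl with trifluoromethyl on this aromatic carbon brings a 3.3-fold higher number from compound 2 to compound 4 (0.52 log units; beyond the scatter), the first step in this set measured between compounds that differ in one place. The group on this carbon therefore matters: this single change is enough to move the number beyond the scatter, towards an effect only at larger amounts of compound, although the step is modest. Nothing shown here bears on why the number moves.

This single step cannot tell whether a chlorine atom, a methoxy group or an amine on the same carbon would stay close to compound 2 or move further from it. It also leaves open whether the same change on the core of compound 1 would bring a similar step.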